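Removing the 4-chlorobenzyl from the indole nitrogen of compound 1

The source may hold more compounds than are shown below. What is called first, only, known or untested is meant among the compounds shown, and "the series" means these compounds.

Compound 1 `N#C/C(=C\c1cn(Cc2ccc(Cl)cc2)c2ccccc12)C(=O)c1c[nH]c2ccccc12` carries a 4-chlorobenzyl group on one of its two indole-type nitrogens. In a functional assay on A549 cells (Homo sapiens) for cytotoxicity, read by WST assay, with a stated time of 48 h (a lower number here means a stronger inhibitor, a higher number a weaker inhibitor), compound 1 gives only a limit, > 50000 nM. Compound 3 `COc1ccc2c(C(=O)/C(C#N)=C/c3cn(Cc4ccc(Cl)cc4)c4ccccc34)c[nH]c2c1` differs from compound 1 by a methoxy in place of hydrogen on an aromatic carbon. Like compound 1, compound 3 also gives only a limit, > 50000 nM. The step that the two limits leave unreadable from compound 1 to compound 3 is therefore not readable. Within the data shown here, compound 2 `COc1ccc2c(/C=C(\C#N)C(=O)c3c[nH]c4cc(OC)ccc34)c[nH]c2c1`, with free ring nitrogens and two methoxy groups, gives 1700 nM in this assay; no single-place step connects it to the others, so only the two values can be compared. Compound 4 `N#C/C(=C\c1c[nH]c2ccccc12)C(=O)c1c[nH]c2ccccc12` arises from compound 1 by the change (hydrogen in place of 4-chlorobenzyl on an aromatic nitrogen). Because the limit of > 50000 nM in this assay, at which 2 of the 3 values shown sit, holds for both compounds bearing the 4-chlorobenzyl, while compound 2, lacking it, gives a measurable value, compound 4 is expected to fall inside the measurable range, though weaker than compound 2. Compound 4 is estimated at 12000 nM, between 2500 nM and 50000 nM. This estimate means an expected step of an at least 4.1-fold lower number from compound 1 to compound 4 (0.61 log units; beyond the scatter), whose size the limit leaves uncertain.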

Compound 4, half-maximal inhibitory concentration: 22000 nM
The estimate for compound 4 lay 1.8-fold (0.26 log units) below the measured number, within the range that was stated.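

In this assay, compound 1 gives only a limit, > 50000 nM. Placing hydrogen where the 4-chlorobenzyl stood on the aromatic nitrogen gives the first readable step in this set, an at least 2.2-fold lower number from compound 1 to compound 4 (0.35 log units; beyond the scatter), so this position affects the read-out, whereas the methoxy change left only two limits that could not be compared. Compound 1 and compound 3, the two compounds carrying the 4-chlorobenzyl, both stay at the limit: the limit of > 50000 nM in this assay, at which 2 of the 4 values shown sit.

Going by these compounds, the full size of the step remains open, as the limit fixes only its smallest possible size. The compounds shown also leave open how a methyl group or a 2-aminoethyl chain on this nitrogen would read, and whether any group there can match or improve on hydrogen.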